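The source may hold more compounds than are shown below. What is called first, only, known or untested is meant among the compounds shown, and "the series" means these compounds.

Measured compounds:
compound 1, `Cc1cc(OC(=O)OCCCCC(CO[N+](=O)[O-])O[N+](=O)[O-])n(-c2ccccc2)n1`: 4.63
compound 2, `Cc1cc(OC(=O)c2ccc(OCCCO[N+](=O)[O-])cc2)n(-c2ccccc2)n1`: 4.74
compound 3, `Cc1cc(OC(=O)C(C)(C)CO[N+](=O)[O-])n(-c2ccccc2)n1`: 3.55

Of the compounds shown here, three sharing one core have been read in a physicochemical assay for lipophilicity, read by HPLC, measured as octanol-water partition, at pH 7; on this read-out lower numbers stand for lower lipophilicity and higher numbers for higher lipophilicity. Compound 2 stands at the top of the three numbers, though compound 1 lies within the usual scatter of it, so the two cannot be ordered. Going by the values given here, compound 3 lies well beyond the scatter below both and is the one clearly lower value of the set.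

Compound 4, `Cc1cc(OC(=O)c2ccc(OCC(CO[N+](=O)[O-])O[N+](=O)[O-])cc2)n(-c2ccccc2)n1`, has not yet been measured. It differs from compound 2 in a single place: nitrooxy in place of hydrogen on a saturated chain carbon bound to two saturated chain carbons. Among the compounds with values here, no pair among the measured compounds isolates this particular change, so no measured step tells its size directly. What the data do show is that compound 1, which carries two nitrooxy groups on its chain, gives a value in this assay that lies within the scatter of compound 2, which carries one.

On that basis the writer expects the change from compound 2 to compound 4 to move the reading little, if at all, with a step of a number 0.11 log units higher from compound 2 to compound 4 (within the scatter) that stays within the scatter and leans, if anywhere, slightly upward. Compound 4 is therefore estimated at 4.85, with a likely range from 4.4 to 5.3.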

Compound 4, partition coefficient: 5.14
Estimate against measurement, compound 4: 0.29 log units below; measured number inside the range.
By their numbers in this assay, from the lowest: compound 3; then compounds 1 and 2 (each within the scatter of the next); then compound 4.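

In this assay, nitrooxy in place of hydrogen on a saturated chain carbon bound to two saturated chain carbons gives a number 0.40 log units higher from compound 2 to compound 4 (beyond the scatter) as a modest change that stands clear of the usual scatter. Going by these compounds alone, until this pair, no two compounds in the set differed in one place only, so this is the first direct reading of what a change at this position does, and it shows that the 3-(nitrooxy)propyl to 2,3-bis(nitrooxy)propyl change on this chain can be told apart from repeat noise. No supporting measurement is available to explain the size or direction of this step.

The compounds shown give this change at one position on one chain only, so it remains open whether the same change would give a step of similar size on a longer chain or at another saturated chain carbon. It also remains open whether the step is particular to nitrooxy, since the compounds shown do not include a hydroxyl group, an amine or a carboxylic acid on this same carbon.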